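Removing a trifluoromethyl from the urea-bearing ring

A few compounds are considered here, and "the series" means these few. Any claim that something is new, unique, unknown or untested is made for them only; others in the source may bear on it.

Of the compounds shown here, three sharing one core have been measured in a functional assay on BT-549 cells (Homo sapiens) for inhibition, read by sulforhodamine B assay, with a stated time of 48 h, tested at 0.01 uM; on this read-out lower numbers stand for a stronger effect and higher numbers for a weaker effect at the one concentration tested. Compound 1 `O=C(Nc1cccc(-n2cc(-c3ccncc3)c(-c3cc(O)cc(Cl)c3)n2)c1)Nc1ccc(Cl)c(C(F)(F)F)c1` gives 102%. Compound 2 `O=C(Nc1cccc(-n2cc(-c3ccncc3)c(-c3cc(O)cc(Cl)c3)n2)c1)Nc1ccc(Cl)c(Cl)c1` gives 94%, and the step of a number 8 percentage points lower from compound 1 to compound 2 (within the scatter) stays within the scatter. Compound 3 `COc1cc(Cl)cc(-c2nn(-c3cccc(NC(=O)Nc4cc(C(F)(F)F)cc(C(F)(F)F)c4)c3)cc2-c2ccncc2)c1` gives 94%, level with compound 2 at the digits shown and together with it the lowest of the three numbers, while compound 1 sits slightly higher, again within the scatter. Compound 4 `COc1cc(Cl)cc(-c2nn(-c3cccc(NC(=O)Nc4cccc(C(F)(F)F)c4)c3)cc2-c2ccncc2)c1` is not yet measured; it differs from compound 3 by hydrogen in place of trifluoromethyl on an aromatic carbon. Going by the values given here, the only measured step, that from compound 1 to compound 2, also altered a group on this ring and changed nothing beyond the scatter, so for compound 4 no step beyond the scatter is expected in this assay, an estimated a number 2 percentage points higher from compound 3 to compound 4 (within the scatter). Compound 4 is therefore estimated at 96%, within 84% to 108%.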

Compound 4, a percentage reported as activity, at one concentration (the size of the read-out at that concentration, not a potency): 107%
Estimate against measurement, compound 4: 11 percentage points below; the measured number falls inside the stated range.
By their numbers in this assay, from the lowest: compounds 2, 3, 1 and 4 (each within the scatter of the next, the first and the last beyond it).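

In this assay, hydrogen in place of trifluoromethyl gives a number 13 percentage points higher from compound 3 to compound 4 (beyond the scatter) and so a weaker effect at the one concentration tested. This makes an aromatic carbon meta to a trifluoromethyl group the one place among these compounds where a single change goes beyond the scatter, though only modestly. Nothing available here accounts for this step.

On these data alone, whether an amine or a nitrile at this position would match compound 3 remains open. So does whether the same change would matter with the hydroxy group of compound 1 on the shared core.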